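Ring swap on the amide of a bis-sulfonamide piperidine series

The source may report more compounds than this note shows. Statements on the series, on what has been measured and on what is new or still open speak of the compounds shown alone.

Measured compounds:
compound 1 `CCN(CC)S(=O)(=O)c1ccc(S(=O)(=O)N2CCC[C@@H](C(=O)NC3CCOCC3)C2)cc1`: 3770 nM
compound 2 `CCN(CC)S(=O)(=O)c1ccc(S(=O)(=O)N2CCC[C@@H](C(=O)N[C@H]3CCOC3)C2)cc1`: 1670 nM
compound 3 `CCN(CC)S(=O)(=O)c1ccc(S(=O)(=O)N2CCC[C@@H](C(=O)N3CCC(COC)CC3)C2)cc1`: 250 nM

In a functional assay on MIA PaCa-2 cells (Homo sapiens) for inhibition, read by MTT assay, with a stated time of 7 days (a higher number here means a weaker inhibitor, a lower number a stronger inhibitor), compound 3 gives the lowest number of the three. The step of a 15-fold lower number from compound 1 to compound 3 (1.18 log units; beyond the scatter) and the step of a 6.7-fold lower number from compound 2 to compound 3 (0.82 log units; beyond the scatter) both lowered the number on moving to compound 3, while the step of a 2.3-fold lower number from compound 1 to compound 2 (0.35 log units; beyond the scatter) was smaller. Compound 4 `CCN(CC)S(=O)(=O)c1ccc(S(=O)(=O)N2CCC[C@@H](C(=O)N3CCS(=O)(=O)CC3)C2)cc1` is derived from compound 3 by the change (1,1-dioxothiomorpholin-4-yl in place of 4-(methoxymethyl)piperidin-1-yl on a carbonyl carbon). Going by the values given here, no measured step involves this change; the steps known here concern the replacement of an amino group bearing a ring by a ring nitrogen on the carbonyl carbon, and compound 4 keeps a ring nitrogen there, as compound 3 does. Among the compounds with values here, with no direct precedent, the estimate for compound 4 leans on compound 3 as the nearest measured point, allowing for a modest weakening, so compound 4 is expected to give 800 nM in this assay, in the range 200 nM to 3200 nM. The expected step is a 3.2-fold higher number from compound 3 to compound 4 (0.51 log units; beyond the scatter).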

Compound 4, half-maximal inhibitory concentration: 900 nM
Beside the measured number, compound 4's estimate is 1.1-fold (0.05 log units) below it; the range from low to high includes it.
By their numbers in this assay, from the lowest: compound 3; then compounds 4 and 2 (each within the scatter of the next); then compound 1.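

In this assay, the ring nitrogen on the carbonyl carbon is kept in both compounds, yet replacing 4-(methoxymethyl)piperidin-1-yl with 1,1-dioxothiomorpholin-4-yl still gives a modest step (a 3.6-fold higher number from compound 3 to compound 4 (0.56 log units; beyond the scatter)), so a ring nitrogen at this position does not alone fix the number. The comparison with the amino-linked rings divides: 1,1-dioxothiomorpholin-4-yl stands beyond the scatter against (oxan-4-yl)amino (a 4.2-fold lower number from compound 1 to compound 4 (0.62 log units; beyond the scatter)), whereas it cannot be told apart from (oxolan-3-yl)amino (a 1.9-fold lower number from compound 2 to compound 4 (0.27 log units; within the scatter)).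

The compounds shown leave open how a morpholin-4-yl group on the same carbonyl carbon would compare, and whether a primary amine or a longer ether chain in place of the methoxymethyl group would keep the number of compound 3. Nothing available accounts for any of these differences.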